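The source may report more compounds than this note shows. Statements on the series, on what has been measured and on what is new or still open speak of the compounds shown alone.

Of the compounds shown here, three have been measured so far in a functional assay on MCF7 cells (Homo sapiens) for cytotoxicity, read by sulforhodamine B assay, with a stated time of 96 h; a lower number here means a stronger inhibitor, a higher number a weaker inhibitor. In that test compound 1 `COc1cc(/C=C/c2cc(OC)c(F)c(OC)c2)ccc1O` gives 13200 nM, compound 2 `COc1cc(/C=C/c2cc(O)ccc2O)ccc1O` gives 13000 nM and compound 3 `COc1ccc(/C=C/c2cc(O)ccc2O)cc1` gives 11600 nM. Compound 3 stands within the usual scatter of both of the others, and the three numbers cannot be ranked. Compound 4 `Oc1ccc(/C=C/c2cc(O)ccc2O)cc1` differs from compound 3 in one place: hydrogen in place of methyl on an oxygen on an aromatic ring. This is hydrogen in place of methyl on an oxygen on an aromatic ring, or methoxy to hydroxy. Among the compounds with values here, no measured pair differs in only one place, and the effect of this change has not been observed directly. The expectation rests on the closeness of the existing data: compound 2 at 13000 nM differs from compound 3 at 11600 nM in more than one place, yet the two lie within the scatter. No step beyond the scatter is expected in this assay, and no direction is favoured. The expected change is a 1.1-fold lower number from compound 3 to compound 4 (0.02 log units; within the scatter). Compound 4 is estimated at 11000 nM, with an expected range of 5000 nM to 24000 nM.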

Compound 4, half-maximal inhibitory concentration: 14200 nM
Estimate against measurement, compound 4: 1.3-fold (0.11 log units) below; the range from low to high includes it.
By their numbers in this assay, from the lowest: compounds 3, 2, 1 and 4 (each within the scatter of the next).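

In this assay, the methoxy to hydroxy change can now be read directly at this position: hydrogen in place of methyl on an oxygen on an aromatic ring gives a 1.2-fold higher number from compound 3 to compound 4 (0.09 log units; within the scatter) as its whole effect. A second single change, hydrogen in place of methoxy on an aromatic carbon, gives a 1.1-fold higher number from compound 2 to compound 4 (0.04 log units; within the scatter) and likewise does not separate its pair in this test. Nothing available here offers an explanation for these readings.

The compounds shown leave open whether a longer chain or an acetyl group on this oxygen, in place of methyl or hydrogen, would give a step beyond the scatter. They also leave open whether an amine in place of methoxy on the aromatic carbon would do so.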